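The source may report more compounds than this note shows. Statements on the series, on what has been measured and on what is new or still open speak of the compounds shown alone.

Among the compounds with values here, in a functional assay on PANC-1 cells (Homo sapiens) for inhibition, read by MTT assay, with a stated time of 24 h (on this read-out lower numbers stand for stronger inhibition and higher numbers for weaker inhibition), compound 3 (`CC1(C)[C@H]2CC[C@]1(C)N(Cc1cn(-c3cccc(O)c3)nn1)C(=O)C2`) gives 280 nM, the highest of the three numbers so far. Compound 1 (`CC1(C)[C@H]2CC[C@]1(C)N(Cc1cn(-c3ccc(F)cc3)nn1)C(=O)C2`) gives 110 nM and compound 2 (`COc1ccccc1-n1cc(CN2C(=O)C[C@@H]3CC[C@@]2(C)C3(C)C)nn1`) gives 120 nM, with a 1.1-fold higher number from compound 1 to compound 2 (0.04 log units; within the scatter). Compound 4 (`COc1ccc(-n2cc(CN3C(=O)C[C@@H]4CC[C@@]3(C)C4(C)C)nn2)cc1`) differs from compound 3 as follows: 4-methoxyphenyl in place of 3-hydroxyphenyl on an aromatic nitrogen. It carries 4-methoxyphenyl in place of 3-hydroxyphenyl on an aromatic nitrogen. Within the data shown here, two measured steps bear on this change, both modest and both ending at 3-hydroxyphenyl: a 2.5-fold higher number from compound 1 to compound 3 (0.41 log units; beyond the scatter) and a 2.3-fold higher number from compound 2 to compound 3 (0.37 log units; beyond the scatter). Among the measured compounds shown here, no measured compound carries 4-methoxyphenyl, so a similar modest move back toward lower numbers is only an expectation. The expected step is a 2.2-fold lower number from compound 3 to compound 4 (0.33 log units; beyond the scatter). For compound 4 the estimate is 130 nM, with an expected range of 65 nM to 280 nM.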

Compound 4, half-maximal inhibitory concentration: 330 nM
Compound 4: the middle estimate sits 2.5-fold (0.40 log units) below what was measured; measured number above the stated range.
By their numbers in this assay, from the lowest: compounds 1 and 2 (each within the scatter of the next); then compounds 3 and 4 (each within the scatter of the next).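

In this assay the place of the methoxy on the phenyl ring now matters, since 4-methoxyphenyl in place of 2-methoxyphenyl gives a 2.8-fold higher number from compound 2 to compound 4 (0.44 log units; beyond the scatter) and so does not match the earlier methoxy compound. Methoxy in place of fluoro on the same aromatic carbon gives a 3.0-fold higher number from compound 1 to compound 4 (0.48 log units; beyond the scatter) as a step of similar size, whereas the change to 4-methoxyphenyl from 3-hydroxyphenyl gives a 1.2-fold higher number from compound 3 to compound 4 (0.07 log units; within the scatter) and so leaves the two groups level. No measurement offered here accounts for these differences. Still open, as far as these compounds go, is how 3-methoxyphenyl would compare with 3-hydroxyphenyl. Also open, from the compounds shown here alone, is how an amine or a carboxylic acid on the phenyl ring would read.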